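A few compounds are considered here, and "the series" means these few. Any claim that something is new, unique, unknown or untested is made for them only; others in the source may bear on it.

Measured compounds:
- compound 1, `COc1cc2c(Oc3ccc(NC(=O)c4cn(-c5ccccc5OC)cn4)cc3F)ccnc2cc1OCCCN1CCN(C)CC1`: 70 nM
- compound 2, `COc1cc2c(Oc3ccc(NC(=O)c4cn(-c5ccc(Cl)cc5)cn4)cc3F)ccnc2cc1OCCCN1CCN(C)CC1`: 5200 nM
- compound 3, `COc1cc2c(Oc3ccc(NC(=O)c4cn(-c5ccc(Cl)cc5Cl)cn4)cc3F)ccnc2cc1OCCCN1CCN(C)CC1`: 3850 nM

In a functional assay on A549 cells (Homo sapiens) for cytotoxicity, read by MTT assay, with a stated time of 72 h (a higher number here means a weaker inhibitor, a lower number a stronger inhibitor), compound 1 stands lowest of the three numbers, with compound 3 nearest and compound 2 furthest. Both measured steps away from compound 1 are large: a 74-fold higher number from compound 1 to compound 2 (1.87 log units; beyond the scatter) and a 55-fold higher number from compound 1 to compound 3 (1.74 log units; beyond the scatter). The step of a 1.4-fold lower number from compound 2 to compound 3 (0.13 log units; within the scatter) is within the scatter. All three of these steps alter the aryl group on the aromatic nitrogen and leave the rest of the molecule untouched.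

Compound 4, `COc1cc2c(Oc3ccc(NC(=O)c4cn(-c5ccccc5OC)cn4)cc3F)ccnc2cc1OCCCN1CCCCC1`, differs from compound 1 elsewhere: piperidin-1-yl in place of 4-methylpiperazin-1-yl on a saturated chain carbon, three bonds along the chain from an oxygen on an aromatic ring. For the measured compounds named here, no measured step in this set bears on that position; the aryl group on the aromatic nitrogen, the part that drove the measured steps, is the same in compound 4 as in compound 1, where compound 1 gives its low number. Going by the values given here, with no step to draw on, the working expectation for compound 4 is a number close to that of compound 1, the step of a 1.4-fold higher number from compound 1 to compound 4 (0.15 log units; within the scatter) being expected to stay within or near the scatter. The estimate for compound 4 in this assay is 100 nM, with a range from 30 nM to 400 nM.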

Compound 4, half-maximal inhibitory concentration: 120 nM
The estimate for compound 4 lay 1.2-fold (0.08 log units) below the measured number; the measured number falls inside the stated range.
By their numbers in this assay, from the lowest: compounds 1 and 4 (each within the scatter of the next); then compounds 3 and 2 (each within the scatter of the next).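

In this assay, the change at the end of the propyl chain, piperidin-1-yl in place of 4-methylpiperazin-1-yl, gives a 1.7-fold higher number from compound 1 to compound 4 (0.23 log units; within the scatter). For the compounds shown here, this is the first reading at this position: with 2-methoxyphenyl on the aromatic nitrogen, the 4-methylpiperazin-1-yl group is not required to keep the low number, and the step stands well apart from the large change of a 74-fold higher number from compound 1 to compound 2 (1.87 log units; beyond the scatter) at the aryl group. No available evidence accounts for the size of this step at the chain end.

As far as these compounds go, whether piperidin-1-yl behaves the same way with 4-chlorophenyl or 2,4-dichlorophenyl on the aromatic nitrogen remains open. Also open, from the compounds shown here alone, is how morpholin-4-yl, dimethylamino or a 2-(piperidin-1-yl)ethyl chain would read at this position.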